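The source may hold more compounds than are shown below. What is called first, only, known or untested is meant among the compounds shown, and "the series" means these compounds.

Series notes on the ring-fused hydrazide set. Compound 1 `CO[C@@H]1CC=C2NN(c3cc4ccccc4[nH]3)C(=O)C[C@]2(C)O1`, compound 2 `CO[C@@H]1CC=C2NN(c3cc4ccccc4[nH]3)C(=O)C[C@]2(c2ccccc2)O1` and compound 3 `COc1cc(OC)cc(N2NC3=CC[C@@H](OC)O[C@@]3(c3ccccc3)CC2=O)c1` have been measured in a functional assay on SK-BR-3 cells (Homo sapiens) for inhibition, read by sulforhodamine B assay, with a stated time of 48 h; on this read-out higher numbers stand for weaker inhibition and lower numbers for stronger inhibition. In this assay compound 1 gives 4100 nM, compound 2 gives 530 nM and compound 3 gives 1200 nM. Compound 2 and compound 1 differ in one place, (methyl in place of phenyl on a saturated ring carbon), and that change gives a 7.7-fold higher number from compound 2 to compound 1 (0.89 log units; beyond the scatter) in this assay. The cores of compound 2 and compound 3 differ in more than one place; that difference is not broken down here, and the two values alone show compound 3 at a higher number than compound 2.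

Compound 4 `COc1cc(OC)cc(N2NC3=CC[C@@H](OC)O[C@@]3(C)CC2=O)c1` has not yet been measured. It differs from compound 3 by methyl in place of phenyl on a saturated ring carbon. Among the compounds with values here, this is the same kind of change as the one from compound 2 to compound 1, but not the same: in the earlier pair the group sat on a saturated ring carbon of a six-membered non-aromatic ring with 1 oxygen, next to the ring oxygen and next to the ring atom that bears a fused ring; here it sits on a saturated ring carbon of a six-membered non-aromatic ring with 2 nitrogen, two ring bonds from the ring nitrogen and three ring bonds from the ring atom that bears a large group.

For this assay the expected step is a 5.8-fold higher number from compound 3 to compound 4 (0.77 log units; beyond the scatter), resting on the earlier step of a 7.7-fold higher number from compound 2 to compound 1 (0.89 log units; beyond the scatter) and allowing for the different surroundings. Compound 4 is therefore estimated at 7000 nM, with a range expected between 2500 nM and 25000 nM.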

Compound 4, half-maximal inhibitory concentration: 5700 nM
Compound 4: the middle estimate sits 1.2-fold (0.09 log units) above what was measured; low and high end bracket the measured number.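

In this assay, methyl in place of phenyl on a saturated ring carbon gives a 4.8-fold higher number from compound 3 to compound 4 (0.68 log units; beyond the scatter), and this step does not separate from the earlier one on the core of compound 1: the same change on two cores in this assay, a 7.7-fold higher number (0.89 log units; beyond the scatter) from compound 2 to compound 1 and a 4.8-fold higher number (0.68 log units; beyond the scatter) from compound 3 to compound 4, 1.6-fold (0.21 log units) apart, within the scatter of two such steps.
Within the compounds shown, the change therefore carries from one core to the other, with each phenyl compound at a lower number than its methyl partner and no sign that the group on the ring nitrogen alters the step.
Within the data shown here, this rests on only two pairs in a single cell assay, so it does not show that the step would hold on a third core or in another read-out, and it says nothing about why phenyl gives the lower number.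

From the compounds shown here alone, only phenyl and methyl have been compared at this saturated ring carbon, so it remains open how a longer chain such as butyl, a benzyl group or a phenyl ring carrying an amine or a carboxylic acid would fall in this assay. Going by these compounds, it also remains open whether the step would keep its size with a group on the ring nitrogen other than the two seen here, such as a pyridine ring.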